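This account rests on a few compounds, and the source may have more. Where it says the series, first, only, none or still open, it means among the compounds named here.

Compound 1 `COc1cc(Nc2nc(Nc3ccc4c(ccn4C)c3)nnc2Cl)cc(OC)c1OC` gives 28100 nM in a functional assay on MGC-803 cells (Homo sapiens) for inhibition, read by MTT assay, with a stated time of 48 h; a lower number here means a stronger inhibitor, a higher number a weaker inhibitor.
Compound 2 `CCOC(=O)c1ccc(Nc2nnc(Cl)c(Nc3cc(OC)c(OC)c(OC)c3)n2)cc1` gives 53600 nM in this assay.
Compound 3 `COc1cc(Nc2nc(Nc3ccccc3)nnc2Cl)cc(OC)c1OC` gives 8750 nM in this assay.

Among the three measured compounds, compound 3 has the lowest number, and both steps that lead to it lie beyond the scatter: a 3.2-fold lower number from compound 1 to compound 3 (0.51 log units; beyond the scatter) and a 6.1-fold lower number from compound 2 to compound 3 (0.79 log units; beyond the scatter). Compound 3 is thus the strongest inhibitor of the set so far, with the unsubstituted anilino group.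

Compound 4 `COc1cc(Nc2nc(Nc3ccc(C(C)=O)cc3)nnc2Cl)cc(OC)c1OC` has not yet been measured. It differs from compound 3 in one place: acetyl in place of hydrogen on an aromatic carbon. Within the data shown here, the step that bears most directly on this change is the one from compound 2 to compound 3, in which an ethoxycarbonyl on the phenyl ring was replaced by hydrogen and the number fell by a 6.1-fold lower number from compound 2 to compound 3 (0.79 log units; beyond the scatter). The acetyl entering in compound 4 is, like ethoxycarbonyl, a carbonyl-bearing group at the same place, para to a large group. A step in the opposite direction to that of compound 2 to compound 3 is therefore expected, that is a higher number in this assay, of modest size and beyond the scatter. For compound 4 the expected step is a 3.4-fold higher number from compound 3 to compound 4 (0.54 log units; beyond the scatter). Compound 4 is accordingly estimated to give about 30000 nM in this assay, within a range from 12000 nM to 80000 nM.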

Compound 4, half-maximal inhibitory concentration: 13000 nM
For compound 4 the middle estimate is 2.3-fold (0.36 log units) above the measured one; the measured number falls inside the stated range.
By their numbers in this assay, from the lowest: compounds 3 and 4 (each within the scatter of the next); then compounds 1 and 2 (each within the scatter of the next).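

In this assay, the step of a 1.5-fold higher number from compound 3 to compound 4 (0.17 log units; within the scatter) lies within the scatter, so placing an acetyl on this aromatic carbon, para to a large group, produces no change that can be claimed, and compound 3 and compound 4 cannot be ordered. The step of a 4.1-fold lower number from compound 2 to compound 4 (0.62 log units; beyond the scatter) lies beyond the scatter and shows that a carbonyl-bearing group at this place does not by itself go with the higher number of compound 2; here the two differ only in methyl in place of ethoxy on the carbonyl carbon, while the step of a 2.2-fold lower number from compound 1 to compound 4 (0.33 log units; beyond the scatter) also places the 4-acetylphenyl compound on the lower side of the indole compound. No measurement given here accounts for either of these differences.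

The compounds shown leave open how an amine, a carboxylic acid or a longer chain on the carbonyl carbon, such as propanoyl, would read at this same place. They also leave open whether an acetyl on another carbon of the phenyl ring would stay within the scatter of compound 3.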